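Swapping acetyl for carbamoylmethyl on the amine nitrogen

A few compounds are considered here, and "the series" means these few. Any claim that something is new, unique, unknown or untested is made for them only; others in the source may bear on it.

Compound 1 `Cc1cn([C@@H]2O[C@H](CO[Si](C)(C)C(C)(C)C)[C@@]3(OS(=O)(=O)C=C3NCCC(=O)OCc3ccccc3)[C@H]2O[Si](C)(C)C(C)(C)C)c(=O)n(C)c1=O`: > 250000 nM (a limit of the assay, not a number)
Compound 2 `Cc1cn([C@@H]2O[C@H](CO[Si](C)(C)C(C)(C)C)[C@@]3(OS(=O)(=O)C=C3NCC(=O)C(N)=O)[C@H]2O[Si](C)(C)C(C)(C)C)c(=O)n(C)c1=O`: 9590 nM
Compound 3 `CC(=O)NC1=CS(=O)(=O)O[C@@]12[C@@H](CO[Si](C)(C)C(C)(C)C)O[C@@H](n1cc(C)c(=O)n(C)c1=O)[C@@H]2O[Si](C)(C)C(C)(C)C`: 10700 nM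

In a functional assay on MT4 cells (Homo sapiens) (on this read-out higher numbers stand for lower toxicity in this test and lower numbers for higher toxicity in this test), the three measured compounds share one core and differ only in the group on an amine nitrogen. Compound 1 gave only a limit, (the limit of > 250000 nM in this assay, at which 1 of the 3 values shown sits). Compound 2 and compound 3 sit within the scatter of each other, the step being a 1.1-fold higher number from compound 2 to compound 3 (0.05 log units; within the scatter). Compound 4 `Cc1cn([C@@H]2O[C@H](CO[Si](C)(C)C(C)(C)C)[C@@]3(OS(=O)(=O)C=C3NCC(N)=O)[C@H]2O[Si](C)(C)C(C)(C)C)c(=O)n(C)c1=O` has not been measured; it differs from compound 3 by carbamoylmethyl in place of acetyl on an amine nitrogen. The steps of an at least 26-fold lower number from compound 1 to compound 2 (1.41 log units; beyond the scatter) and an at least 23-fold lower number from compound 1 to compound 3 (1.36 log units; beyond the scatter) were large, but both start from compound 1 with its benzyloxycarbonyl chain. The step that bears most directly on the change is a 1.1-fold higher number from compound 2 to compound 3 (0.05 log units; within the scatter): a carbamoyl-containing group and acetyl on that nitrogen gave numbers within scatter, and carbamoylmethyl also contains a carbamoyl group. No step beyond the scatter is therefore expected. Compound 4 is estimated at 11000 nM, with a range from 4000 nM to 40000 nM. This estimate means an expected step of a 1.0-fold higher number from compound 3 to compound 4 (0.01 log units; within the scatter).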

Compound 4, half-maximal cytotoxic concentration: 14900 nM
The estimate for compound 4 lay 1.4-fold (0.13 log units) below the measured number, within the range that was stated.
By their numbers in this assay, from the lowest: compounds 2, 3 and 4 (each within the scatter of the next). At a limit, above all of these: compound 1.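

Carbamoylmethyl in place of acetyl on the amine nitrogen brings in a hydrogen-bond donor that acetyl lacks, yet the number stays within the scatter (a 1.4-fold higher number from compound 3 to compound 4 (0.14 log units; within the scatter)), and the same holds for amino in place of carbamoyl on the carbonyl carbon (a 1.6-fold higher number from compound 2 to compound 4 (0.19 log units; within the scatter)). These three groups on that nitrogen therefore cannot be told apart in this assay, and only the chain carrying benzyloxycarbonyl stands apart (an at least 16-fold lower number from compound 1 to compound 4 (1.22 log units; beyond the scatter)). That step starts from a limit of the assay, not a number: the limit of > 250000 nM in this assay, at which 1 of the 4 values shown sits.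

As far as these compounds go, whether the benzyl ring or the ester of that chain goes with the limit stays open, and a carboxylic acid on the same chain would help separate the two. Also open, from the compounds shown here alone, is whether a free amine or a longer chain ending in carbamoyl would stay within the scatter of these three.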